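Working notes: compound 1 to compound 4

This account rests on a few compounds, and the source may have more. Where it says the series, first, only, none or still open, it means among the compounds named here.

Compound 1 `O=C(c1cnco1)N1CCC(C(=O)N2N=CC[C@H]2c2ccccc2)CC1` gives 2.7 in a physicochemical assay for lipophilicity, read by HPLC, measured as chromatographic lipophilicity, at pH 7.4 (a lower number here means a more polar compound, a higher number a more lipophilic compound), the second highest of three measured numbers. Compound 2 `O=C(c1cn[nH]c1)N1CCC(C(=O)N2N=CCC2c2ccccc2)CC1` stands lower at 2.1 and compound 3 `N#Cc1nccc(N2CCC(C(=O)N3N=CC[C@H]3c3cc(F)cc(F)c3)CC2)n1` stands higher at 5.1, both gaps beyond the scatter. Compound 4 `O=C(C1CCN(c2cccnn2)CC1)N1N=CC[C@H]1c1ccccc1` has pyridazin-3-yl in place of (1,3-oxazol-5-yl)carbonyl on an amine nitrogen in a ring. Among the compounds with values here, no measured pair isolates this change, so the expectation stays anchored on compound 1 at 2.7 and allows for the wide spread of the series. A small rise in this assay is expected, little beyond the scatter (a number 0.40 log units higher from compound 1 to compound 4 (beyond the scatter)). Compound 4 is expected at an estimated value (3.1), within an estimated range (2.4 to 3.8).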

Compound 4, distribution coefficient: 3.4
Compound 4: the middle estimate sits 0.30 log units below what was measured, within the range that was stated.
By their numbers in this assay, from the lowest: compound 2; then compound 1; then compound 4; then compound 3.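

Within the data shown here, on an amine nitrogen in a ring, pyridazin-3-yl in place of (1,3-oxazol-5-yl)carbonyl gives the first step in this assay that changes only one place, a number 0.70 log units higher from compound 1 to compound 4 (beyond the scatter). The change swaps the aromatic ring and removes the carbonyl together, so this single step cannot divide its size between the two.

A pyridazin-3-ylcarbonyl group or a phenyl group on that same nitrogen would remain to be read in this series. No measurement shown here accounts for the size of the step.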